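Replacing a Bicyclic Amine on a Piperazine Sulfonamide Antagonist

This account rests on a few compounds, and the source may have more. Where it says the series, first, only, none or still open, it means among the compounds named here.

Compound 1 `CN(Cc1ccc(C2=NCCN2)cc1)C(=O)COCCN(C)S(=O)(=O)c1c(Cl)cccc1Cl`: 8.5
Compound 2 `COc1cc(C)c(S(=O)(=O)N(C)CCOCC(=O)N2CCN([C@H]3CN4CCC3CC4)CC2)c(C)c1`: 7.2
Compound 3 `CN(Cc1ccc(C2=NCCN2)cc1)C(=O)COCCN(C)S(=O)(=O)c1c(F)cccc1F`: 7.6

In a functional assay on Umbilical vein for antagonist activity at B1 bradykinin receptor (Homo sapiens), using Schild analysis, with a stated time of 30 min (a lower number here means a less potent compound, a higher number a more potent compound, by a factor of ten per unit of this negative logarithm), compound 1 gives 8.5, compound 3 gives 7.6 and compound 2 gives 7.2. Compound 2 stands lowest of the three: compound 3 is nearest to it, compound 1 furthest, both gaps beyond the scatter. Among the measured compounds shown here, the only measured step, a number 0.90 log units lower from compound 1 to compound 3 (beyond the scatter), concerns the ring on the sulfonyl sulfur and says nothing about the amine end that changes here.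

Compound 4 `COc1cc(C)c(S(=O)(=O)N(C)CCOCC(=O)N2CCN(CCN(C)C)CC2)c(C)c1` differs from compound 2 in one place: a group of 5 heavy atoms (4 carbon, 1 nitrogen; no ring) in place of a group of 8 heavy atoms (7 carbon, 1 nitrogen; 2 six-membered non-aromatic rings with 1 hetero atom each), on an amine nitrogen in a ring. For the measured compounds named here, no measured step bears on this change, so the expectation rests on compound 2 alone, with wide uncertainty and no direction beyond the scatter. Compound 4 is expected to give 6.9 in this assay, between 6 and 7.7. The expected step is a number 0.30 log units lower from compound 2 to compound 4 (within the scatter).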

Compound 4, negative logarithm of the antagonist equilibrium constant: 7.4
Compound 4: middle estimate off by 0.50 log units, on the low side; measured number inside the range.
By their numbers in this assay, from the lowest: compounds 2, 4 and 3 (each within the scatter of the next, the first and the last beyond it); then compound 1.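

On an amine nitrogen in a ring, the open-chain 2-(dimethylamino)ethyl group takes the place of the two-ring group and gives a number 0.20 log units higher from compound 2 to compound 4 (within the scatter) in this assay. In this one pair, therefore, the two six-membered non-aromatic rings and the defined stereocentre are not needed to hold the number. No measurement at hand offers a reason for this result.

The compounds shown leave open whether a longer chain such as 3-(dimethylamino)propyl, or a chain ending in a carboxylic acid, would hold the number at this place. They also leave open how a primary amine at the chain end would compare.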